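Benzyl Amide Variant of a Stilbene-Linked Pyridine Carboxamide

The source may report more compounds than this note shows. Statements on the series, on what has been measured and on what is new or still open speak of the compounds shown alone.

Compound 1, `O=C(Nc1ccccc1)c1cc(Oc2ccc(/C=C/c3ccccn3)cc2)ccn1`: 30200 nM
Compound 2, `O=C(Nc1ccccc1)c1cc(Oc2ccc(/C=C/c3ccncc3)cc2)ccn1`: > 100000 nM

Compound 1 in a functional assay on HepG2 cells (Homo sapiens) for antiproliferative activity, read by CCK-8 assay, with a stated time of 48 h (on this read-out higher numbers stand for weaker inhibition and lower numbers for stronger inhibition), gives 30200 nM. Compound 2 is reported only as a limit in this assay, > 100000 nM. Among the measured compounds shown here, the single measured step, an at least 3.3-fold higher number from compound 1 to compound 2 (0.51 log units; beyond the scatter), thus runs from a number up to the limit, (the limit of > 100000 nM in this assay, at which 1 of the 2 values shown sits). Compound 2 therefore stands at the weak end of the two values shown, and its true position is known only as that limit.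

Compound 3, `O=C(NCc1ccccc1)c1cc(Oc2ccc(/C=C/c3ccncc3)cc2)ccn1`, differs from compound 2 in one place: benzyl in place of phenyl on an amide-type nitrogen. No measured step touches the amide nitrogen; the only step shown, the exchange of one pyridyl ring for another on the double-bonded chain carbon, does not bear on this change. There is thus no basis in the numbers shown for expecting a step in either direction in this assay beyond the scatter, and the starting point is itself a limit. Compound 3 is accordingly expected to remain near that limit, the estimated step being a number no higher from compound 2 to compound 3 (the limit leaves the size open). The estimate for compound 3 in this assay is 100000 nM, with an expected range from 30000 nM to 300000 nM.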

Compound 3, half-maximal inhibitory concentration: 28900 nM
For compound 3 the middle estimate is 3.5-fold (0.54 log units) above the measured one, and the stated range ends above it.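

In this assay, the exchange of phenyl for benzyl on the amide-type nitrogen gives an at least 3.4-fold lower number from compound 2 to compound 3 (0.53 log units; beyond the scatter). Among the compounds shown here, the amide nitrogen, which no earlier step touched, is thus a second place at which these compounds respond, alongside the pyridyl exchange on the double-bonded chain carbon, and this one change is enough to bring a compound carrying pyridin-4-yl from a limit to a measured number. The true size of the step stays open because compound 2 is reported only as a limit: the limit of > 100000 nM in this assay, at which 1 of the 3 values shown sits.

As far as these compounds go, whether benzyl gives a step of similar direction when pyridin-2-yl stands on the chain remains open, so the two changes cannot yet be said to act independently of each other. Also open, from the compounds shown here alone, is what a longer chain on the amide-type nitrogen, such as phenethyl, or an amine or a carboxylic acid carried on the benzyl group would do to the number in this assay.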